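This account rests on a few compounds, and the source may have more. Where it says the series, first, only, none or still open, it means among the compounds named here.

Measured compounds:
compound 1, `COc1ccc(OC)c(/C=N/NC(=O)Nc2ccc(Oc3ccnc(-c4nncn4CCN(C)C)c3)c(F)c2)c1`, 1950 nM
compound 2, `CN(C)CCn1cnnc1-c1cc(Oc2ccc(NC(=O)N/N=C/c3ccc(O)cc3)cc2F)ccn1`, 3560 nM

In a functional assay on A549 cells (Homo sapiens) for cytotoxicity, read by MTT assay, with a stated time of 72 h (on this read-out higher numbers stand for weaker inhibition and lower numbers for stronger inhibition), compound 2 stands at the highest of the two numbers; its nearest neighbour is compound 1, and the step of a 1.8-fold higher number from compound 1 to compound 2 (0.26 log units; within the scatter) lies within the scatter. Compound 3, `Cc1cc(/C=N/NC(=O)Nc2ccc(Oc3ccnc(-c4nncn4CCN(C)C)c3)c(F)c2)cc(C)c1O`, has not yet been measured. It differs from compound 2 in one place: 4-hydroxy-3,5-dimethylphenyl in place of 4-hydroxyphenyl on a carbon with a double bond to nitrogen. For the measured compounds named here, only one measured step bears on changes at this carbon, the exchange of the aryl group from compound 1 to compound 2, and that step was small. A further exchange of the same aryl group, here the addition of two methyl groups to the 4-hydroxyphenyl, therefore gives no basis to expect a step beyond the scatter in either direction. Compound 3 is expected to show a 1.2-fold lower number from compound 2 to compound 3 (0.07 log units; within the scatter) in this assay. The estimate for compound 3 is 3000 nM, with a range from 1200 nM to 8000 nM.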

Compound 3, half-maximal inhibitory concentration: 1640 nM
For compound 3 the middle estimate is 1.8-fold (0.26 log units) above the measured one, within the range that was stated.
By their numbers in this assay, from the lowest: compounds 3, 1 and 2 (each within the scatter of the next, the first and the last beyond it).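

In this assay, for the compounds shown here, adding two methyl groups to the 4-hydroxyphenyl gives a 2.2-fold lower number from compound 2 to compound 3 (0.34 log units; beyond the scatter), the first step at this carbon to lie beyond the scatter, though only modestly. The aryl group on this carbon can therefore move the number, yet the exchange of 2,5-dimethoxyphenyl for 4-hydroxy-3,5-dimethylphenyl gives a 1.2-fold lower number from compound 1 to compound 3 (0.08 log units; within the scatter), so these two aryl groups cannot be told apart here. Nothing shown explains why the two methyl groups produce this step.

From the compounds shown here alone, it remains open whether a single methyl group would give part of the step, and whether the hydroxyl is needed once both methyl groups are present. Also unresolved is how an amine or a carboxylic acid on this aryl ring would read in this assay, or how a chloro or methoxy group would compare with methyl.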